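A few compounds are considered here, and "the series" means these few. Any claim that something is new, unique, unknown or untested is made for them only; others in the source may bear on it.

In a functional assay on DLD-1 cells (Homo sapiens) for cytotoxicity, read by MTT assay (a higher number here means a weaker inhibitor, a lower number a stronger inhibitor), compound 1 (`COc1cc(/C=C/C(=O)C(=Cc2ccc(O)c(O)c2)C(=O)/C=C/c2ccc(O)c(OC)c2)ccc1O`) gives 17600 nM and compound 2 (`CCOc1cc(/C=C/C(=O)C(=Cc2ccc(O)c(OC)c2)C(=O)/C=C/c2ccc(O)c(OCC)c2)ccc1O`) gives 9630 nM so the two stand within the scatter of each other, and neither can be ranked. Compound 3 (`CCOc1cc(/C=C/C(=O)C(=Cc2ccc(OC)c(OC)c2)C(=O)/C=C/c2ccc(O)c(OCC)c2)ccc1O`) carries, relative to compound 2, the change methyl in place of hydrogen on an oxygen on an aromatic ring (methyl in place of hydrogen on an oxygen on an aromatic ring, hydroxy to methoxy). Among the compounds with values here, no measured pair shows this change, so the expected step of a 1.1-fold higher number from compound 2 to compound 3 (0.06 log units; within the scatter) is none beyond the scatter, with no direction favoured. In this assay compound 3 is expected at 11000 nM (estimated range 4500 nM to 26000 nM).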

Compound 3, half-maximal inhibitory concentration: 42000 nM
Beside the measured number, compound 3's estimate is 3.8-fold (0.58 log units) below it; measured number above the stated range.
By their numbers in this assay, from the lowest: compounds 2 and 1 (each within the scatter of the next); then compound 3.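

Methyl in place of hydrogen on an oxygen on an aromatic ring, hydroxy to methoxy, is the first single-place change in the series, and it gives a 4.4-fold higher number from compound 2 to compound 3 (0.64 log units; beyond the scatter) in this assay. This oxygen is therefore not silent: 3,4-dimethoxyphenyl reads weaker than 4-hydroxy-3-methoxyphenyl, on this one pair only. No supporting data bear on the reason for this step. Open, going by these compounds, is whether a longer chain such as propyl on this oxygen would move the number further. Also open, on these data alone, is whether an amine in place of the methoxy would restore the number of compound 2.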